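Cyclopropyl-methylidene purines: sulfanyl versus amino substituent

The source may report more compounds than this note shows. Statements on the series, on what has been measured and on what is new or still open speak of the compounds shown alone.

Measured compounds:
compound 1, `CCCSc1nc(N)nc2c1ncn2/C=C1/CC1(CO)CO` — > 20000 nM
compound 2, `CC(C)Nc1nc(N)nc2c1ncn2/C=C1/CC1(CO)CO` — "not determined" (no result reported)

Compound 1 carries a propylsulfanyl group on the shared core. In an ADME assay on MOLT-3 cells (Homo sapiens) for cytotoxicity, with a stated time of 7 days (on this read-out lower numbers stand for higher toxicity in this test and higher numbers for lower toxicity in this test), compound 1 gives only a limit of the assay, > 20000 nM. Compound 2 carries isopropylamino in the same place; for compound 2 this assay reports "not determined" (no result reported), so no number stands for it. Among the measured compounds shown here, the one further value shown, that of compound 1, is a limit of the assay (the limit of > 20000 nM in this assay, at which 1 of the 2 values shown sits).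

Compound 3, `CCCCCCCCSc1nc(N)nc2c1ncn2/C=C1/CC1(CO)CO`, differs from compound 2 by octylsulfanyl in place of isopropylamino on an aromatic carbon. For the measured compounds named here, with no measured number for compound 2, no step can be computed, and the direction of any change in this assay remains open; a small shift, at most modest, is expected. For compound 3 a half-maximal cytotoxic concentration of about 15000 nM is estimated, between 4000 nM and 40000 nM, with a fair chance that only a limit is reported.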

Compound 3, half-maximal cytotoxic concentration: > 20000 nM
Compound 3 was reported as a limit; the forecaster's own chance of this, stated with the estimate: 55%; middle value at least 1.3-fold (0.12 log units) away from the limit.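

Compound 3 gives > 20000 nM in this assay, a limit of the assay. No step can be read between compound 1 and compound 3, since both stand at a limit: the limit of > 20000 nM in this assay, at which 2 of the 3 values shown sit.

The compounds shown leave open how far cytotoxicity differs between the propylsulfanyl and octylsulfanyl compounds, and where compound 2 stands.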